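Aryl variation on the triazole of a shared core

This account rests on a few compounds, and the source may have more. Where it says the series, first, only, none or still open, it means among the compounds named here.

Of the compounds shown here, three sharing one core have been measured in a functional assay on A549 cells (Homo sapiens) for antiproliferative activity, read by MTT assay, with a stated time of 48 h; a higher number here means a weaker inhibitor, a lower number a stronger inhibitor. Compound 1 `Cc1cccc(-n2nncc2CN2C(=O)C3(C(C#N)=C(N)Oc4c3c3nc5ccccc5nc3c3ccccc43)c3ccccc32)c1` gives 39600 nM. Compound 2 `N#CC1=C(N)Oc2c(c3nc4ccccc4nc3c3ccccc23)C12C(=O)N(Cc1cnnn1-c1ccccc1Cl)c1ccccc12` gives 42600 nM. Compound 3 `N#CC1=C(N)Oc2c(c3nc4ccccc4nc3c3ccccc23)C12C(=O)N(Cc1cnnn1-c1cccc(Cl)c1)c1ccccc12` gives 32600 nM. Compound 3 has the smallest of the three numbers, but its separation from the others is slight: a 1.2-fold lower number from compound 1 to compound 3 (0.08 log units; within the scatter) and a 1.3-fold lower number from compound 2 to compound 3 (0.12 log units; within the scatter), both within the scatter, as is a 1.1-fold higher number from compound 1 to compound 2 (0.03 log units; within the scatter). Every change so far has been a swap of the aryl group on the triazole nitrogen, and none of them moved the number beyond the scatter.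

Compound 4 `COc1ccccc1-n1nncc1CN1C(=O)C2(C(C#N)=C(N)Oc3c2c2nc4ccccc4nc2c2ccccc32)c2ccccc21` is the next member of the same kind: 2-methoxyphenyl in place of 3-chlorophenyl on an aromatic nitrogen. This change again touches only the aryl group on the triazole nitrogen, the same place varied in all three measured steps, each of which stayed within the scatter. The expectation is therefore that compound 4 will show no step beyond the scatter from compound 3 in this assay, with a 1.1-fold higher number from compound 3 to compound 4 (0.04 log units; within the scatter) as the estimated step. Compound 4 is accordingly expected to give about 36000 nM, with a range from 17000 nM to 75000 nM.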

Compound 4, half-maximal inhibitory concentration: > 50000 nM
Compound 4: no number, only a limit; the forecaster's own chance of this, stated with the estimate: 5%; middle value at least 1.3-fold (0.14 log units) away from the limit.
By their numbers in this assay, from the lowest: compounds 3, 1 and 2 (each within the scatter of the next). At a limit, above all of these: compound 4.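

In this assay, among the compounds shown here, compound 4 is the first of the series to give a limit rather than a number: the limit of > 50000 nM in this assay, at which 1 of the 4 values shown sits. The steps are therefore floors, not sizes: an at least 1.5-fold higher number from compound 3 to compound 4 (0.18 log units; that floor lies within the scatter), an at least 1.1-fold higher number from compound 2 to compound 4 (0.06 log units; that floor lies within the scatter) and an at least 1.2-fold higher number from compound 1 to compound 4 (0.10 log units; that floor lies within the scatter). All three floors lie within the scatter, so this change at the aromatic nitrogen, where 2-methoxyphenyl brings one hydrogen-bond acceptor and the earlier aryl groups bring none, cannot yet be said to have moved the number beyond the scatter, though the limit also leaves room for a larger step than any seen among compounds 1, 2 and 3.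

The compounds shown leave open how far the true value of compound 4 lies from its limit, and whether methoxy in place of chloro would read the same with the group on the 3-position of the phenyl ring, as in 3-methoxyphenyl. They also leave open how an unsubstituted phenyl, a hydroxyl, an amine or a carboxylic acid on this aryl ring would read in this assay.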